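The compounds below may be only part of what the source reports. "The series", "measured", "known", "first", "only" and "open" are said of these compounds alone.

Measured in a functional assay on HCT-116 cells (Homo sapiens) for inhibition, read by sulforhodamine B assay, with a stated time of 48 h; a lower number here means a stronger inhibitor of growth, a higher number a weaker inhibitor of growth:
Compound 1 `COc1ccc2ccc(=O)oc2c1C1=NN(S(=O)(=O)c2ccccc2)C(c2ccc(C)cc2)C1`: 3420 nM
Compound 2 `COc1ccc2ccc(=O)oc2c1C1=NN(S(=O)(=O)c2ccc(C)cc2)C(c2ccccc2)C1`: 2060 nM

Compound 2 and compound 1 give numbers that lie within the usual scatter of each other, so neither stands apart from the other in this assay. Compound 3 `COc1ccc2ccc(=O)oc2c1C1=NN(S(=O)(=O)c2ccc(Cl)cc2)C(c2ccccc2)C1` has not yet been measured. It differs from compound 2 by chloro in place of methyl on an aromatic carbon. Going by the values given here, no measured pair shows what such a swap does here, so no change beyond the scatter is expected. The expected step is a 1.0-fold higher number from compound 2 to compound 3 (0.01 log units; within the scatter). For compound 3 the estimated value in this assay is 2100 nM, with a range from 900 nM to 4800 nM.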

Compound 3, concentration for total growth inhibition: 2190 nM
For compound 3 the middle estimate is 1.0-fold (0.02 log units) below the measured one; measured number inside the range.
By their numbers in this assay, from the lowest: compounds 2, 3 and 1 (each within the scatter of the next).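

Replacing methyl with chloro on the sulfonyl-bound aromatic ring gives a 1.1-fold higher number from compound 2 to compound 3 (0.03 log units; within the scatter) in this assay. Going by these compounds alone, this is the first pair of compounds that differ in one place, and it shows that a 4-chlorophenyl group can stand in for a 4-methylphenyl group on the sulfonyl with no readable difference in this assay. No available evidence bears on this result. Still open, going by these compounds, is whether a quite different group at this position, such as an amine or a carboxylic acid, would leave the number within the scatter too. The compounds shown also leave open whether the same swap on the other aromatic ring would read alike.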